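The source may hold more compounds than are shown below. What is called first, only, known or untested is meant among the compounds shown, and "the series" means these compounds.

Measured compounds: compound 1, `ClCc1cccc(Cn2cnc3ncnc(Cl)c32)c1`, 67600 nM in a functional assay on KM12 cells (Homo sapiens) for cytotoxicity, read by sulforhodamine B assay, with a stated time of 48 h; on this read-out higher numbers stand for lower toxicity in this test and lower numbers for higher toxicity in this test; compound 2, `ClCc1cccc(Cn2cnc3c(Cl)nc(Cl)nc32)c1`, 7940 nM.

Compound 1 gives the higher of the two numbers in this assay; compound 2 lies well beyond the scatter from it. Compound 3, `ClCc1cccc(Cn2cnc3nc(Cl)nc(Cl)c32)c1`, has not yet been measured. It differs from compound 1 by chloro in place of hydrogen on an aromatic carbon. For the measured compounds named here, no single-place step between measured compounds exists to anchor this change, so the expectation rests on the two values alone. Compound 3 is expected to fall clearly below compound 1, a step of a 5.6-fold lower number from compound 1 to compound 3 (0.75 log units; beyond the scatter), with an estimated value of 12000 nM and a range of 3000 nM to 45000 nM.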

Compound 3, concentration lethal to 50% of the cells: 74100 nM
Estimate against measurement, compound 3: 6.2-fold (0.79 log units) below; measured number above the stated range.
By their numbers in this assay, from the lowest: compound 2; then compounds 1 and 3 (each within the scatter of the next).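

In this assay, chloro in place of hydrogen on an aromatic carbon between two ring nitrogen atoms gives a 1.1-fold higher number from compound 1 to compound 3 (0.04 log units; within the scatter), a step within the scatter. For the compounds shown here, this is the first single-place step available here, and it shows that this position can carry a chloro group with no detectable shift in the read-out. Nothing measured here accounts for this result.

As far as these compounds go, whether an amine, a methoxy group or a hydroxyl group at this position would shift the number in this assay remains open. So does whether chloro would give the same result on a different carbon of the shared core.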